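Bromophenyl ring pattern and Huh-7 cytotoxicity in the series

This account rests on a few compounds, and the source may have more. Where it says the series, first, only, none or still open, it means among the compounds named here.

Compound 3 `O=c1cc(CNCc2cccc(Br)c2)oc2ccc(O)c(O)c12` is characterised in an ADME assay on Huh-7 cells (Homo sapiens) for cytotoxicity; on this read-out higher numbers stand for lower toxicity in this test and lower numbers for higher toxicity in this test. In this assay compound 3 gives > 100000 nM, which is a limit of the assay and not a number. Compound 1 `O=c1cc(CNCc2ccccc2Br)oc2ccc(O)c(O)c12` likewise returns a limit in this assay, namely > 100000 nM. For the measured compounds named here, compound 2 `O=c1cc(CNCc2ccccc2I)oc2ccc(O)c(O)c12` gives 87300 nM in this assay, the only plain number of the three. The evidence is bounded by the limit of > 100000 nM in this assay, at which 2 of the 3 values shown sit.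

The measured steps are small or unreadable: an at least 1.1-fold lower number from compound 1 to compound 2 (0.05 log units; that floor lies within the scatter); an at least 1.1-fold higher number from compound 2 to compound 3 (0.05 log units; that floor lies within the scatter); and a step that the two limits leave unreadable from compound 1 to compound 3. None of them separates a compound from the others beyond the scatter.

Compound 4 `O=c1cc(CNCc2ccc(Br)cc2)oc2ccc(O)c(O)c12` differs from compound 3 by 4-bromophenyl in place of 3-bromophenyl on a saturated chain carbon bound to an amine nitrogen. The measured steps that bear on this change are the two that also move the bromophenyl pattern, the step from compound 1 to compound 3 and the step from compound 2 to compound 3, and neither of them shows a readable shift. The expected step is therefore none beyond the scatter, a number no higher from compound 3 to compound 4 (the limit leaves the size open), with compound 4 most likely reported again as a limit. Compound 4 is estimated at 100000 nM in this assay, within a range from 55000 nM to 200000 nM.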

Compound 4, half-maximal cytotoxic concentration: > 100000 nM
Compound 4 was reported as a limit; the forecaster's own chance of this, stated with the estimate: 70%; the middle value lies on the limit itself.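

In this assay the 4-bromophenyl group ends at the same limit as the 2-bromophenyl and 3-bromophenyl groups, so the whole set of bromine ring patterns in the series now gives no plain number, and the series' readings at this place rest on the limit: the limit of > 100000 nM in this assay, at which 3 of the 4 values shown sit. The steps among compound 1, compound 3 and compound 4 cannot be read, as both ends of each are limits, and shifting the bromine from the 3-bromophenyl to the 4-bromophenyl pattern therefore adds no measurable difference. For the compounds shown here, the one step that can be read is an at least 1.1-fold higher number from compound 2 to compound 4 (0.05 log units; that floor lies within the scatter), so 4-bromophenyl in place of 2-iodophenyl separates the two compounds by nothing beyond the scatter, and the only plain number stays unseparated from the limit.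

As far as these compounds go, how far the three bromophenyl compounds lie past the limit remains open, and with it any order among them. Also open, from the compounds shown here alone, is whether a different group on the phenyl ring in place of the bromine, such as a carboxylic acid, an amine or a longer chain, would give a plain number in this assay.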